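Amide cap variation on the shared core: methylcyclopropyl

The source may report more compounds than this note shows. Statements on the series, on what has been measured and on what is new or still open speak of the compounds shown alone.

Compound 1 `CCC(=O)N1CC2CC(C1)N2` sets the reference point of the series; in an assay on SH-EP1 cells for agonist activity at Neuronal acetylcholine receptor; alpha4/beta2 (Homo sapiens), read by FLIPR and calcium flux (a lower number here means a smaller maximal response, a higher number a larger maximal response), compound 1 gives 110%. Compound 2 `O=C([C@H]1C[C@H]1F)N1CC2CC(C1)N2` and compound 3 `O=C([C@@H]1C[C@H]1F)N1CC2CC(C1)N2` carry 2-fluorocyclopropyl in place of ethyl on a carbonyl carbon, and in this assay compound 2 gives 110% and compound 3 gives 110%. The steps of no change at the digits printed from compound 1 to compound 2 (within the scatter) and no change at the digits printed from compound 1 to compound 3 (within the scatter) are both within the scatter, as is no change at the digits printed from compound 2 to compound 3 (within the scatter), where the two compounds share atoms and bonds and differ in how one stereocentre at a saturated ring carbon is drawn (the fact that one of compounds 2 and 3 is drawn with a defined configuration and the other without, at the place where they differ). Compound 3 therefore stands level with compound 1 and compound 2 at the digits shown, with no compound in the set separated from another beyond the scatter.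

Compound 4 `C[C@H]1C[C@@H]1C(=O)N1CC2CC(C1)N2` is not yet measured. The change from compound 3 to compound 4 is 2-methylcyclopropyl in place of 2-fluorocyclopropyl on a carbonyl carbon. The measured steps that bear on it are the cap exchanges from compound 1, which left the maximal response unchanged, and the stereochemical pair, which also left it unchanged. Among the compounds with values here, no step in this assay has moved the maximal response beyond the scatter, so for compound 4 the expected step is no change at the digits printed from compound 3 to compound 4 (within the scatter), none beyond the scatter. The estimate for compound 4 in this assay is 110%, with a range from 95% to 125%.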

Compound 4, largest response reached (Emax), in percent of the reference or control that the assay uses: 85%
For compound 4 the middle estimate is 25 percentage points above the measured one, outside the stated range (below it).
By their numbers in this assay, from the lowest: compound 4; then compounds 1, 2 and 3 (each within the scatter of the next).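

At the position on a carbonyl carbon whose other neighbours are an amide-type nitrogen in a ring, the cap can change the maximal response in this assay after all: 2-methylcyclopropyl gives a number 25 percentage points lower from compound 3 to compound 4 (beyond the scatter) and a number 25 percentage points lower from compound 2 to compound 4 (beyond the scatter) when it replaces 2-fluorocyclopropyl, and a number 25 percentage points lower from compound 1 to compound 4 (beyond the scatter) when it replaces ethyl. The cyclopropyl ring alone therefore does not fix the response, since 2-fluorocyclopropyl and 2-methylcyclopropyl share the ring and the heavy-atom count yet differ beyond the scatter, with carbon in place of fluorine as the difference in atoms. Nothing measured here gives a cause for this step.

As far as these compounds go, only one configuration of 2-methylcyclopropyl appears, so the role of its stereochemistry remains open. Unsubstituted cyclopropyl or a longer chain such as butyl would show whether the lower response is specific to the methyl-bearing ring.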